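From 4-aminophenyl to 2-hydroxyethyl on a triple bond

The source may hold more compounds than are shown below. What is called first, only, known or untested is meant among the compounds shown, and "the series" means these compounds.

Of the compounds shown here, three have been tested so far in a functional assay on SK-MEL-147 cells (Homo sapiens) for cytotoxicity, read by MTT assay, with a stated time of 24 h; a higher number here means that more compound is needed for the effect, a lower number that less compound is needed. Compound 1 `CCOC(=O)c1cc(C#Cc2ccc(N)cc2)c2cc(OC)ccc2n1` gives 8800 nM, the lower of the two actual numbers. Compound 3 `CCOC(=O)c1cc([Se]Cc2ccccc2)c2cc(Cl)ccc2n1` gives 84500 nM, and the gap between these two values lies beyond the usual scatter of repeated measurements. Compound 2 `CCOC(=O)c1cc([Se]c2ccc(OC)cc2)c2cc(OC)ccc2n1` returns only a limit, >= 54300 nM. Compound 1 therefore stands lowest among the numbers available, meaning that less of it is needed for the effect.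

Compound 4 `CCOC(=O)c1cc(C#CCCO)c2cc(OC)ccc2n1` keeps the core of compound 1 and its triple bond, but the group at the end changes: 2-hydroxyethyl comes in place of 4-aminophenyl on a triple-bonded carbon (2-hydroxyethyl in place of 4-aminophenyl on a triple-bonded carbon). The aromatic ring of carbon leaves with that group, and no ring enters.

Going by the values given here, no tested pair isolates this change, so any forecast is uncertain. Among the compounds with values here, compound 1 at 8800 nM is the only tested compound that carries 4-aminophenyl, and nothing yet shows that its value would survive losing it. In this assay, a rise beyond the scatter seems likely, and the expected move is a 4.0-fold higher number from compound 1 to compound 4 (0.60 log units; beyond the scatter). For compound 4 the estimated value is 35000 nM, with an expected range from 10000 nM to 100000 nM.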

Compound 4, half-maximal effective concentration: > 150000 nM
Compound 4: only a limit was reported (the forecaster's own chance of this, stated with the estimate: 30%); middle value at least 4.2-fold (0.63 log units) away from the limit.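

Compound 4 returns only a limit, and the comparison rests on it: the limit of > 150000 nM in this assay, at which 1 of the 4 values shown sits. In this assay, going by these compounds alone, this is the first direct comparison at this position, and the step is an at least 17-fold higher number from compound 1 to compound 4 (1.23 log units; beyond the scatter), so replacing 4-aminophenyl with 2-hydroxyethyl on the triple-bonded carbon costs a large part of the effect. The hydrogen-bond donor and acceptor counts are the same for the group that leaves and the group that enters, so those counts alone do not separate compound 1 from compound 4, whereas the aromatic ring of carbon and the number of heavy atoms do differ.

The compounds shown cannot tell whether the ring itself or the amine on it matters more, and a plain phenyl group on the same triple bond would help separate the two. They also leave open how a longer chain ending in a hydroxyl group would compare, and how far the real value of compound 4 lies from its limit.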